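This account rests on a few compounds, and the source may have more. Where it says the series, first, only, none or still open, it means among the compounds named here.

Compound 1 `c1ccc(-c2cc(NCC3CC3)ncn2)nc1` stands at the high end of the two numbers in hand: in a functional assay on HEK293 cells for agonist activity at G-protein coupled receptor 39 (Mus musculus), read by inositol phosphate accumulation (on this read-out lower numbers stand for an effect already at smaller amounts and higher numbers for an effect only at larger amounts of compound), compound 1 gives 10000 nM, while compound 2 `Cc1nc(NCc2ccc(Cl)cc2)cc(-c2ccccn2)n1` gives 17 nM in this assay, a gap well beyond the scatter. Compound 3 `CN(C)c1nc(NCC2CC2)cc(-c2ccccn2)n1` differs from compound 1 by dimethylamino in place of hydrogen on an aromatic carbon. Among the measured compounds shown here, no single-change step is available to calibrate this substitution. With compound 2 showing that a substituted core can reach low values, a modest downward step a 3.3-fold lower number from compound 1 to compound 3 (0.52 log units; beyond the scatter) is expected, but uncertainty is wide. Compound 3 is estimated at 3000 nM, with a range from 500 nM to 20000 nM.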

Compound 3, half-maximal effective concentration: 6720 nM
Compound 3: the middle estimate sits 2.2-fold (0.35 log units) below what was measured, within the range that was stated.
By their numbers in this assay, from the lowest: compound 2; then compounds 3 and 1 (each within the scatter of the next).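

In this assay, dimethylamino in place of hydrogen on an aromatic carbon, between two ring nitrogen atoms, gives a 1.5-fold lower number from compound 1 to compound 3 (0.17 log units; within the scatter) with the (cyclopropylmethyl)amino group held constant. At this position, the two groups are therefore not separated by this read-out. Nothing in hand explains this result.

Going by these compounds, whether a carboxylic acid or a primary amine at this position would separate from hydrogen remains open. Also open, on these data alone, is whether dimethylamino gives the same result with a different group in place of (cyclopropylmethyl)amino.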